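Thioether arm variation on the shared core

The source may report more compounds than this note shows. Statements on the series, on what has been measured and on what is new or still open speak of the compounds shown alone.

In an assay on CHO cells for displacement of a labelled ligand from adenosine receptor A3 (Homo sapiens), read by scintillation counting, with a stated time of 120 min, tested at 1 uM (on this read-out lower numbers stand for less inhibition and higher numbers for more inhibition at the one concentration tested (going by the name of the read-out)), compound 1 `N#Cc1c(N)nc(SCc2cccnc2)c(C#N)c1-c1ccc(OCC2CC2)cc1` gives 19% and compound 2 `N#Cc1c(N)nc(SCc2ccn[nH]2)c(C#N)c1-c1ccc(OCC2CC2)cc1` gives 6%; the step of a number 13 percentage points lower from compound 1 to compound 2 (beyond the scatter) leaves compound 2 as the lower of the two numbers. Compound 3 `COC(=O)c1cccc(CSc2nc(N)c(C#N)c(-c3ccc(OCC4CC4)cc3)c2C#N)c1` differs from compound 2 by 3-(methoxycarbonyl)phenyl in place of 1H-pyrazol-5-yl on a saturated chain carbon bound to a sulfur. Going by the values given here, only the step from compound 1 to compound 2 bears on this change, and it runs the other way, from a six-membered aromatic ring to a five-membered aromatic ring, so a return toward the level of compound 1 is plausible but weakly supported. Compound 3 is expected to give 15% (range 0% to 40%), an estimated step of a number 9 percentage points higher from compound 2 to compound 3 (within the scatter) in this assay.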

Compound 3, a percentage reported as inhibition, at one concentration (the size of the read-out at that concentration, not a potency): 4%
For compound 3 the middle estimate is 11 percentage points above the measured one; the measured number falls inside the stated range.
By their numbers in this assay, from the lowest: compounds 3 and 2 (each within the scatter of the next); then compound 1.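

On the saturated chain carbon bound to a sulfur, 3-(methoxycarbonyl)phenyl in place of 1H-pyrazol-5-yl gives a number 2 percentage points lower from compound 2 to compound 3 (within the scatter) in this assay, so a carbon-only six-membered ring and a five-membered ring with hetero atoms are not separated here. In place of pyridin-3-yl, the same group gives a number 15 percentage points lower from compound 1 to compound 3 (beyond the scatter), leaving pyridin-3-yl as the only arm of the three set apart from the others. Nothing available explains this. Open, from the compounds shown here alone, is whether a carboxylic acid in place of the methyl ester, or a plain phenyl, would change the number.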